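Dropping One Methoxy Group: An Expected Small Step

This account rests on a few compounds, and the source may have more. Where it says the series, first, only, none or still open, it means among the compounds named here.

Measured so far in a functional assay on OVCAR-5 cells (Homo sapiens) for cytotoxicity, read by sulforhodamine B assay, with a stated time of 48 h, tested at 0.1 uM; on this read-out higher numbers stand for a weaker effect at the one concentration tested and lower numbers for a stronger effect:
- compound 1 `COc1ccc(-c2cc(/C=C/C(=O)c3ccc(N)cc3)[nH]n2)cc1` gives 95%
- compound 2 `COc1cc(-c2cc(/C=C/C(=O)c3ccc(N)cc3)[nH]n2)cc(OC)c1OC` gives 103%
- compound 3 `COc1ccc(C(=O)/C=C/c2cc(-c3cc(OC)c(OC)c(OC)c3)n[nH]2)cc1` gives 97%

Compound 2 stands highest of these three numbers, yet compound 3 is nearest and compound 1 furthest, and both gaps lie within the usual scatter, so the three cannot be told apart on this read-out. Going by the values given here, the only step joined by a single change is a number 6 percentage points lower from compound 2 to compound 3 (within the scatter), which is also within the scatter.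

Compound 4 `COc1ccc(-c2cc(/C=C/C(=O)c3ccc(N)cc3)[nH]n2)cc1OC` has not yet been measured. It differs from compound 2 by hydrogen in place of methoxy on an aromatic carbon.

Among the compounds with values here, no measured step removes a methoxy group, so none bears on this change directly. Within the data shown here, what can be said is that compound 1 and compound 2, which differ only in how many methoxy groups sit on one ring, show values within the scatter of each other, and that the one measured step, a number 6 percentage points lower from compound 2 to compound 3 (within the scatter), likewise left the number where it was. Together these give no reason to expect a step beyond the scatter in this assay in either direction. Compound 4 is therefore expected to give about 99%, within a range from 88% to 110%. The expected step is a number 4 percentage points lower from compound 2 to compound 4 (within the scatter).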

Compound 4, a percentage reported as activity, at one concentration (the size of the read-out at that concentration, not a potency): 95%
Compound 4: the middle estimate sits 4 percentage points above what was measured; the measured number falls inside the stated range.
By their numbers in this assay, from the lowest: compounds 1, 4, 3 and 2 (each within the scatter of the next).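

Taking one methoxy group off the ring now has a direct reading in this assay, at a carbon that is ortho to a methoxy group and meta to a large group: a number 8 percentage points lower from compound 2 to compound 4 (within the scatter). The reverse kind of change, a methoxy group added to that ring, gives no change at the digits printed from compound 1 to compound 4 (within the scatter). Neither single change therefore separates its pair of compounds on this read-out, so at the one concentration tested, the number of methoxy groups on this ring makes no difference that can be read among compounds 1, 2 and 4. No other data on these compounds bear on this result, so the numbers stand without an explanation.

As far as these compounds go, all of these numbers come from a single concentration at which the compounds cannot be told apart, so whether the same changes would matter at other concentrations stays open. Also open, from the compounds shown here alone, is what a different group at this carbon would do, such as a hydroxyl group, a fluorine atom or a longer chain like ethoxy.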